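A few compounds are considered here, and "the series" means these few. Any claim that something is new, unique, unknown or untested is made for them only; others in the source may bear on it.

Measured compounds in an ADME assay on MT4 cells (Homo sapiens) for cytotoxicity, read by MTT assay, with a stated time of 96 h; a lower number here means that less compound is tolerated, a higher number that more compound is tolerated:
Compound 1, `Fc1ccc(F)c(/N=N/Nc2ccccc2)c1`: compound 1 gives 100000 nM.
Compound 2, `CN(C)CCCN(/N=N/c1cc(F)ccc1F)c1ccccc1`: compound 2 gives 13000 nM.
Compound 3, `CN(C)CCCN(/N=N/c1ccccc1)c1cccc(C(F)(F)F)c1`: compound 3 gives 14000 nM.

The cores of compound 2 and compound 3 differ, and that difference is not broken down here; their values in this assay sit within the scatter of each other. From compound 2 to compound 1 the change is hydrogen in place of 3-(dimethylamino)propyl on a nitrogen on an aromatic ring, and it gives a 7.7-fold higher number from compound 2 to compound 1 (0.89 log units; beyond the scatter). Compound 4, `FC(F)(F)c1cccc(N/N=N/c2ccccc2)c1`, is not yet measured. It arises from compound 3 by hydrogen in place of 3-(dimethylamino)propyl on a nitrogen on an aromatic ring, the same change at the same kind of place, so the step is expected to be of similar size. Resting on the step from compound 2 to compound 1, compound 4 is expected to show a 6.4-fold higher number from compound 3 to compound 4 (0.81 log units; beyond the scatter). The estimate for compound 4 is therefore 90000 nM, expected to fall between 35000 nM and 150000 nM.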

Compound 4, half-maximal cytotoxic concentration: > 100000 nM
Compound 4 ended at the assay's limit; the forecaster's own chance of this, stated with the estimate: 40%; at least 1.1-fold (0.04 log units) between middle value and limit.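

In this assay compound 4 gives > 100000 nM as a limit of the assay and not as a number. Hydrogen in place of 3-(dimethylamino)propyl gives an at least 7.1-fold higher number from compound 3 to compound 4 (0.85 log units; beyond the scatter) in the same direction as on the other core, and the two steps stand as follows: the same change on two cores in this assay, a 7.7-fold higher number (0.89 log units; beyond the scatter) from compound 2 to compound 1 and an at least 7.1-fold higher number (0.85 log units; beyond the scatter) from compound 3 to compound 4; the limit leaves it open whether they differ. This shows that the change carried over in direction on these two cores, but it does not show that the step has the same size on both, and two cores say nothing about others.

The compounds shown leave open what a shorter chain, a longer chain or a morpholine in place of 3-(dimethylamino)propyl would give on that nitrogen. They also leave open how the change behaves on a core carrying a carboxylic acid or a nitrile.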